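A few compounds are considered here, and "the series" means these few. Any claim that something is new, unique, unknown or untested is made for them only; others in the source may bear on it.

Compound 1, `CCOc1ccccc1-c1ccc(-c2nc3cnccc3c(N[C@H](CC)C(=O)N(C)C)c2C#N)cc1`, is the more lipophilic of the two measured compounds. In a physicochemical assay for lipophilicity, read by HPLC, at pH 7.5 (a higher number here means a more lipophilic compound, a lower number a more polar compound), compound 1 gives 3.7. Among the measured compounds shown here, compound 2, `CC[C@@H](Nc1c(C#N)c(-c2ccc(-c3ccccc3CO)cc2)nc2cnccc12)C(N)=O`, gives in this assay a value of 2.1, which sits well below compound 1 by a margin beyond the usual scatter, so compound 1 stands highest of the two numbers known.

Compound 3, `CCOc1ccccc1-c1ccc(-c2nc3cnccc3c(NC(CC)CNS(=O)(=O)C3CC3)c2C#N)cc1`, is not yet measured. It differs from compound 1 at the nitrogen on the aromatic ring: a group of 11 heavy atoms (7 carbon, 1 nitrogen, 2 oxygen, 1 sulfur; one three-membered non-aromatic ring of carbon only) in place of a group of 8 heavy atoms (6 carbon, 1 nitrogen, 1 oxygen; no ring), on a nitrogen on an aromatic ring. For the measured compounds named here, no measured pair in this set shows the effect of this exchange, so the size of the step has to be guessed from the structures alone. The group that enters carries a hydrogen-bond donor and one more acceptor than the group that leaves, and the step from compound 1 to compound 3 in this assay is expected to be a modest decrease, a number 0.30 log units lower from compound 1 to compound 3 (within the scatter), close to the scatter. Compound 3 is therefore estimated to reach 3.4 in this assay, within a range from 2.9 to 3.9.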

Compound 3, distribution coefficient: 3.6
Estimate against measurement, compound 3: 0.20 log units below; the measured number falls inside the stated range.
By their numbers in this assay, from the lowest: compound 2; then compounds 3 and 1 (each within the scatter of the next).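

In this assay, putting the group of 11 heavy atoms, with its three-membered non-aromatic ring of carbon only, in place of 1-(dimethylcarbamoyl)propyl on a nitrogen on an aromatic ring gives a number 0.10 log units lower from compound 1 to compound 3 (within the scatter) and so leaves the reading unchanged within the scatter. Among the compounds shown here, this is the first exchange in the set that can be read at one place alone, and it shows that a larger group with 1 hydrogen-bond donor and 2 hydrogen-bond acceptors, against 0 and 1 in the group that leaves, need not move the number beyond the scatter at this nitrogen. Nothing measured here accounts for this step.

The compounds shown leave open whether a carboxylic acid or a primary amine on this nitrogen would also stay within the scatter of compound 1. They also leave open whether the same exchange would give a step of similar size on the core of compound 2, which differs from compound 1 in more than one place.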